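From fluoro to trifluoromethyl on an aromatic carbon

The source may report more compounds than this note shows. Statements on the series, on what has been measured and on what is new or still open speak of the compounds shown alone.

Compound 1 `O=C(CCCCCCC(=O)Nc1ccc(O)cc1)NO` gives 15000 nM in a functional assay on HT-29 cells (Homo sapiens) for antiproliferative activity, with a stated time of 48 h; on this read-out lower numbers stand for an effect already at smaller amounts and higher numbers for an effect only at larger amounts of compound
Compound 2 `O=C(CCCCCCC(=O)Nc1cccc(F)c1)NO` gives 1400 nM in this assay

Of these two numbers, compound 2 holds the lower one, and the gap to compound 1 lies beyond the scatter. Compound 3 `O=C(CCCCCCC(=O)Nc1cccc(C(F)(F)F)c1)NO` has trifluoromethyl in place of fluoro on an aromatic carbon, meta to a large group. Going by the values given here, no measured pair shows this change, so the expectation rests on the structures alone. In this assay no step beyond the scatter is expected (a 1.1-fold higher number from compound 2 to compound 3 (0.03 log units; within the scatter)), in either direction. Compound 3 is estimated at 1500 nM with an expected range (500 nM to 4500 nM).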

Compound 3, half-maximal effective concentration: 6400 nM
Compound 3: middle estimate off by 4.3-fold (0.63 log units), on the low side, outside the stated range (above it).
By their numbers in this assay, from the lowest: compound 2; then compound 3; then compound 1.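

Trifluoromethyl in place of fluoro gives a 4.6-fold higher number from compound 2 to compound 3 (0.66 log units; beyond the scatter) in this assay, so this aromatic carbon, meta to a large group, responds to the exchange. Going by these compounds alone, it is the first step measured between compounds that differ in one place, and the group with 4 heavy atoms carries the higher number, while the group with 1 heavy atom carries the lower. On these data alone, whether chloro, methoxy or an amine on this carbon would stand nearer compound 2 or compound 3 remains open. Nothing shown here explains the size or direction of this step.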